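The source may hold more compounds than are shown below. What is called first, only, known or untested is meant among the compounds shown, and "the series" means these compounds.

Working notes on the series. Compound 1 `Cc1ccccc1NC(=O)c1c(O)c2cccnc2n(-c2ccccc2)c1=O` and compound 2 `O=C(Nc1nccs1)c1c(O)c2cccnc2n(-c2ccccc2)c1=O` share one core and differ only at an amide-type nitrogen. In a functional assay on the whole organism for inhibition, with Rattus norvegicus as the target, read by cytopathic effect and paw edema, at a dose of 100 mg/kg by the oral route (a lower number here means less inhibition, a higher number more inhibition at the dose given (going by the name of the read-out)), compound 1 gives 9.8%, and compound 2 gives 2.5%. For the measured compounds named here, compound 2 stands lowest of the two numbers so far, with compound 1 nearest; the measured step between them is a number 7.3 percentage points lower from compound 1 to compound 2 (within the scatter). Compound 3 `O=C(Nc1ccc(Cl)nc1)c1c(O)c2cccnc2n(-c2ccccc2)c1=O` has not been measured in this assay. It differs from compound 2 in one place: 6-chloropyridin-3-yl in place of 1,3-thiazol-2-yl on an amide-type nitrogen. Going by the values given here, the only step that bears on this change sits at the same amide-type nitrogen, a number 7.3 percentage points lower from compound 1 to compound 2 (within the scatter), and it stayed within the scatter. No step beyond the scatter is therefore expected in this assay for compound 3 in either direction. Compound 3 is expected to give 6%, between 0% and 20%. The expected step is a number 3.5 percentage points higher from compound 2 to compound 3 (within the scatter), within the scatter.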

Compound 3, a percentage reported as inhibition, in the whole organism at one dose (the size of the read-out at that dose, not a potency): -4%
Estimate against measurement, compound 3: 10 percentage points above, outside the stated range (below it).
By their numbers in this assay, from the lowest: compounds 3, 2 and 1 (each within the scatter of the next, the first and the last beyond it).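

In this assay, the change of thiazolyl for chloropyridinyl at this amide-type nitrogen gives a number 6.5 percentage points lower from compound 2 to compound 3 (within the scatter), so these two aromatic rings cannot be told apart here. For the compounds shown here, the new information is a number 13.8 percentage points lower from compound 1 to compound 3 (beyond the scatter), the first step at this position to pass the scatter, and it is modest; 6-chloropyridin-3-yl in place of 2-methylphenyl therefore does change the number, downward. No measurement in hand bears on the reason for this step.

As far as these compounds go, it remains open whether the chlorine of the 6-chloropyridin-3-yl group has any part in that step, which an unsubstituted pyridin-3-yl group would test. From the compounds shown here alone, it also remains open whether a carboxylic acid or an amine on a longer chain at this nitrogen would raise the inhibition beyond the scatter.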